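Substituent variation on the aromatic nitrogen

A few compounds are considered here, and "the series" means these few. Any claim that something is new, unique, unknown or untested is made for them only; others in the source may bear on it.

Compound 3 `C/C(=C\C(=O)Nc1ccccc1OCCCC(=O)O)c1ccc2c(ccn2Cc2ccccc2C)c1` gives 69 nM in an assay on Prostate gland for inhibition of steroid 5-alpha-reductase (Rattus norvegicus) (a lower number here means a stronger inhibitor, a higher number a weaker inhibitor), the highest of the three numbers shown, though within the scatter of both others: compound 1 `CCCCn1ccc2cc(/C(C)=C/C(=O)Nc3ccccc3OCCCC(=O)O)ccc21` gives 43 nM and compound 2 `CCC(C)n1ccc2cc(/C(C)=C/C(=O)Nc3ccccc3OCCCC(=O)O)ccc21` gives 67 nM. Compound 4 `COc1ccc(Cn2ccc3cc(/C(C)=C/C(=O)Nc4ccccc4OCCCC(=O)O)ccc32)cc1` differs from compound 3 by 4-methoxyphenyl in place of 2-methylphenyl on a saturated chain carbon bound to an aromatic nitrogen. Within the data shown here, the steps that bear on this are those that also vary the group on the aromatic nitrogen: a 1.6-fold higher number from compound 1 to compound 3 (0.21 log units; within the scatter) and a 1.0-fold higher number from compound 2 to compound 3 (0.01 log units; within the scatter), together with a 1.6-fold higher number from compound 1 to compound 2 (0.19 log units; within the scatter); all three lie within the scatter. No step beyond the scatter is therefore expected in this assay from the change to compound 4, in either direction. For compound 4 the expected value is 70 nM (range 30 nM to 160 nM). This corresponds to an expected step of a 1.0-fold higher number from compound 3 to compound 4 (0.01 log units; within the scatter).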

Compound 4, half-maximal inhibitory concentration: 480 nM
The estimate for compound 4 lay 6.9-fold (0.84 log units) below the measured number, outside the stated range (above it).
By their numbers in this assay, from the lowest: compounds 1, 2 and 3 (each within the scatter of the next); then compound 4.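

In this assay the group on the aromatic nitrogen is not freely exchangeable: 4-methoxybenzyl stands apart from the three earlier groups, with a 7.0-fold higher number from compound 3 to compound 4 (0.84 log units; beyond the scatter) and a 7.2-fold higher number from compound 2 to compound 4 (0.86 log units; beyond the scatter) and an 11-fold higher number from compound 1 to compound 4 (1.05 log units; beyond the scatter) as the steps that show it. A benzyl group alone does not go with this step: compound 3, with 2-methylbenzyl, stays within the scatter of the butyl and sec-butyl compounds. Nothing at hand bears on the reason for the step.

Open, from the compounds shown here alone, is whether the methoxy group or its place on the ring goes with the step. Also open, going by these compounds, is where unsubstituted benzyl or a hexyl chain on the aromatic nitrogen would fall.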